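A pyridine for a phenyl on the sulfur-linked side chain

The source may hold more compounds than are shown below. What is called first, only, known or untested is meant among the compounds shown, and "the series" means these compounds.

Of the compounds shown here, three of a shared core have been measured in an assay on isolated protein for inhibition of aldehyde dehydrogenase 1A1 (Homo sapiens); on this read-out lower numbers stand for stronger inhibition and higher numbers for weaker inhibition. Compound 1 `C[C@@H](Sc1nc2c(cnn2C)c(=O)n1-c1ccccc1)c1ccccc1` gives 70 nM. Compound 3 `CC(Sc1nc2nn(C3COC3)cc2c(=O)n1-c1ccccc1)c1ccccn1` gives 68 nM, a number within the usual scatter of that of compound 1, so no order can be claimed between these two. Compound 2 `O=c1c2cncn2nc(SCc2cccc(F)c2)n1-c1ccccc1` gives 2200 nM, the weakest inhibition of the three and beyond the scatter from compound 1. Compound 1 therefore stands second highest of the three numbers, close to compound 3 and far from compound 2.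

Compound 4 `CC(Sc1nc2c(cnn2C)c(=O)n1-c1ccccc1)c1cccnc1` differs from compound 1 in one place: 1-(pyridin-3-yl)ethyl in place of 1-phenylethyl on a sulfur. The rest of the molecule is unchanged. Within the data shown here, no pair of measured compounds differs by exactly this swap, so there is no measured step to lean on. Because compound 3, which also carries a nitrogen-containing ring in this side chain, gives 68 nM, a step of no more than the scatter is expected, in no clear direction. Compound 4 is expected to give 90 nM, between 30 nM and 270 nM, which means an expected step of a 1.3-fold higher number from compound 1 to compound 4 (0.11 log units; within the scatter).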

Compound 4, half-maximal inhibitory concentration: 139 nM
Compound 4: middle estimate off by 1.5-fold (0.19 log units), on the low side, and the stated range covers the measured number.
By their numbers in this assay, from the lowest: compounds 3, 1 and 4 (each within the scatter of the next, the first and the last beyond it); then compound 2.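

Replacing 1-phenylethyl with 1-(pyridin-3-yl)ethyl on a sulfur gives, in this assay, a 2.0-fold higher number from compound 1 to compound 4 (0.30 log units; within the scatter), so no order can be claimed between these two compounds. This one-place comparison shows that a carbon of this aromatic ring can give way to a nitrogen, which adds a hydrogen-bond acceptor to the count, without a step beyond the scatter. No evidence here bears on why the two numbers lie so close.

The structure of compound 4 defines no stereocentre in this side chain, whereas that of compound 1 does, so the contribution of the defined stereocentre stays unresolved. Also open, from the compounds shown here alone, is whether a side chain on this sulfur carrying an amine or a carboxylic acid would stay within the same range.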